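Methoxy for methyl on the triazole aryl group

The compounds below may be only part of what the source reports. "The series", "measured", "known", "first", "only" and "open" are said of these compounds alone.

Values in a functional assay on MCF7 cells (Homo sapiens) for cytotoxicity, read by MTT assay, with a stated time of 4 days; a lower number here means a stronger inhibitor, a higher number a weaker inhibitor:
compound 1, `C=C1C[C@]23C[C@@]1(O)CC[C@H]2c1cc(Br)c(O)c(C)c1[C@@H]3Cn1cc(-c2ccc(C)cc2)nn1`: > 20000 nM
compound 2, `Cc1c(O)ccc2c1[C@H](Cn1cc(-c3ccc(Cl)cc3)nn1)[C@@]13CC(=O)[C@@](C)(CC[C@@H]21)C3`: > 20000 nM
compound 3, `C=C1C[C@]23C[C@@]1(O)CC[C@H]2c1ccc(O)c(C)c1[C@@H]3Cn1cc(-c2ccc(C)cc2)nn1`: > 20000 nM

Compound 1 stands at a limit of this assay, not at a number. Compound 2 likewise gives only a limit. Compound 3 likewise gives only a limit. For the measured compounds named here, the one step between measured compounds, hydrogen in place of bromo on an aromatic carbon, a step that the two limits leave unreadable from compound 1 to compound 3, has a limit at both ends and its size cannot be read. The whole picture of the series is summed up by the limit of > 20000 nM in this assay, at which 3 of the 3 values shown sit.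

Compound 4, `C=C1C[C@]23C[C@@]1(O)CC[C@H]2c1cc(Br)c(O)c(C)c1[C@@H]3Cn1cc(-c2ccc(OC)cc2)nn1`, differs from compound 1 by methoxy in place of methyl on an aromatic carbon. No measured step in the series bears on this change, and the one step shown is unreadable, so nothing here points to a move in either direction. With every measured compound sitting at the limit, compound 4 is expected to sit there too, and the step that the limit leaves unreadable from compound 1 to compound 4 is expected to be none beyond the scatter. For compound 4 the estimate in this assay is 30000 nM, within the range 12000 nM to 100000 nM, most probably reported again as a limit rather than a number.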

Compound 4, half-maximal inhibitory concentration: > 20000 nM
Compound 4 ended at the assay's limit; the forecaster's own chance of this, stated with the estimate: 85%; the middle value is on the limit's open side.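

In this assay compound 4 gives > 20000 nM, which is a limit and not a number. Compound 1 also stands at a limit, so no step can be read between compound 1 and compound 4. The compounds shown leave open which structural change, if any, would give a number rather than a limit in this assay, as the series stands at one place: the limit of > 20000 nM in this assay, at which 4 of the 4 values shown sit.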